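Amino in Place of Fluoro on Compound 2

The source may hold more compounds than are shown below. What is called first, only, known or untested is meant among the compounds shown, and "the series" means these compounds.

In a functional assay on B16-F0 cells (Mus musculus) for inhibition, read by CCK-8 assay, with a stated time of 48 h (on this read-out lower numbers stand for stronger inhibition and higher numbers for weaker inhibition), compound 1 `COc1cc(-c2ccnc3cc(-c4ccccc4)nn23)cc(OC)c1OC` gives 4730 nM and compound 2 `COc1ccc(-c2cc3nccc(-c4cc(OC)c(OC)c(OC)c4)n3n2)cc1F` gives 3950 nM. These two values lie within the usual scatter of each other, so compound 2 cannot be ranked ahead of compound 1. Compound 3 `COc1ccc(-c2cc3nccc(-c4cc(OC)c(OC)c(OC)c4)n3n2)cc1N`, not yet measured, has amino in place of fluoro on an aromatic carbon of compound 2 (amino in place of fluoro on an aromatic carbon). Within the data shown here, the only measured step, a 1.2-fold lower number from compound 1 to compound 2 (0.08 log units; within the scatter), puts 3-fluoro-4-methoxyphenyl in place of phenyl and stays within the scatter. Among the measured compounds shown here, it is a weak guide, as no compound with an amino group has been measured yet. A moderate move to a lower number in this assay is therefore a tentative expectation, and a step within the scatter remains possible. The expected change is a 2.6-fold lower number from compound 2 to compound 3 (0.42 log units; beyond the scatter). For compound 3 the estimated value is 1500 nM, with an expected range of 200 nM to 5000 nM.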

Compound 3, half-maximal inhibitory concentration: 88 nM
Compound 3: middle estimate off by 17-fold (1.23 log units), on the high side; the whole stated range lies above it.
By their numbers in this assay, from the lowest: compound 3; then compounds 2 and 1 (each within the scatter of the next).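

Changing one atom on the ring, ortho to a methoxy group, gives a 45-fold lower number from compound 2 to compound 3 (1.65 log units; beyond the scatter) in this assay, so this position is highly sensitive to what sits on it. The earlier step from phenyl to 3-fluoro-4-methoxyphenyl stayed within the scatter and gave no hint of this. Against the plain phenyl of compound 1, the 3-amino-4-methoxyphenyl group gives a 54-fold lower number from compound 1 to compound 3 (1.73 log units; beyond the scatter), which shows that a substituted ring alone is not enough, since the fluoro version of compound 2 does not achieve this.

Nothing available explains why amino and fluoro differ so sharply here. Also open, on these data alone, is whether a hydroxyl, a methylamino or an acetamido group at this place would keep the low number, and whether the amino group still works without the neighbouring methoxy group.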